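One Carbon Added to a Propargylamine Chain

The source may report more compounds than this note shows. Statements on the series, on what has been measured and on what is new or still open speak of the compounds shown alone.

Compound 1, `C#CCN(C)CCCCOc1ccc2c(c1)CCC2=O`: 7.93%
Compound 2, `C#CCN(C)CCCCCOc1ccc2c(c1)CCC2=O`: 31%
Compound 3, `C#CCN(C)CCCCCOc1ccc2c(c1)OCCC2=O`: 6.04%

Of the compounds shown here, three have been measured in an ADME assay on BTI cells for inhibition of Amine oxidase [flavin-containing] A (Homo sapiens), read by fluorescence and Amplex Red, with a stated time of 15 min, tested at 100 uM; on this read-out higher numbers stand for more inhibition at the one concentration tested (going by the name of the read-out) and lower numbers for less inhibition. In this assay compound 1 gives 7.93%, while compound 2 gives 31%. Going by the values given here, the only change between them is (methyl(propargyl)amino)methyl in place of methyl(propargyl)amino on a saturated chain carbon, four bonds along the chain from an oxygen on an aromatic ring, and it produced a number 23.1 percentage points higher from compound 1 to compound 2 (beyond the scatter). Compound 3, which carries a different core, gives 6.04% in this assay; how its core differs from that of compound 1 is not broken down here. Compound 3 and compound 1 give readings that lie within the usual scatter of each other, whereas compound 2 stands apart from both.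

Compound 4, `C#CCN(C)CCCCCCOc1ccc2c(c1)OCCC2=O`, has not yet been measured in this assay. It is related to compound 3 by (methyl(propargyl)amino)methyl in place of methyl(propargyl)amino on a saturated chain carbon, five bonds along the chain from an oxygen on an aromatic ring. Among the compounds with values here, this is the same kind of change as the one from compound 1 to compound 2, but not the same: there the place was four bonds along the chain from an oxygen on an aromatic ring, here it is five bonds along the chain from an oxygen on an aromatic ring, and the core is that of compound 3 rather than compound 1.

Within the data shown here, the expectation for compound 4 is a step of a number 18 percentage points higher from compound 3 to compound 4 (beyond the scatter) in this assay, a guess that rests on the step of a number 23.1 percentage points higher from compound 1 to compound 2 (beyond the scatter) seen for the same kind of change; it is tempered, as the place and core differ and only one such pair is known. Compound 4 is accordingly estimated at 24%, with a plausible range from 4% to 44%.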

Compound 4, a percentage reported as inhibition, at one concentration (the size of the read-out at that concentration, not a potency): 34.1%
Beside the measured number, compound 4's estimate is 10.1 percentage points below it, within the range that was stated.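

In this assay, putting (methyl(propargyl)amino)methyl in place of methyl(propargyl)amino on a saturated chain carbon, five bonds along the chain from an oxygen on an aromatic ring, gave a number 28.1 percentage points higher from compound 3 to compound 4 (beyond the scatter). Set beside the earlier step, the same kind of change carried from the core of compound 1 to the core of compound 3 with no difference in size that can be told apart: the same change on two cores in this assay, a number 23.1 percentage points higher (beyond the scatter) from compound 1 to compound 2 and a number 28.1 percentage points higher (beyond the scatter) from compound 3 to compound 4, 5 percentage points apart, within the scatter of two such steps

Going by these compounds alone, this agreement rests on only two pairs, and since the place on the chain differs along with the core, it cannot show what either difference does alone, nor that the change would carry to any other core or chain length. As the read-out gives inhibition at one concentration, it also says nothing about potency.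

The compounds shown leave open whether a longer chain on either core would go on raising the number or whether the rise would stop. They also leave open whether the propargyl group matters to the step, as a dimethylamine at the end of the same chain would show.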